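A few compounds are considered here, and "the series" means these few. Any claim that something is new, unique, unknown or untested is made for them only; others in the source may bear on it.

Compounds measured so far:
compound 1, `COc1cc2c(cc1OC)C(=O)C(CC1CCN(C(=S)Nc3ccc(C)cc3)CC1)C2`, 100 mg/kg
compound 2, `COc1cc2c(cc1OC)C(=O)C(CC1CCN(C(=S)Nc3ccccc3Cl)CC1)C2`, 300 mg/kg

In a functional assay on the whole organism (strain Swiss albino) with Mus musculus as the target, in the maximal electroshock model, with a stated time of 4 h (a lower number here means that less compound is needed, a higher number that more compound is needed for the effect), compound 2 stands at the highest of the two numbers; its nearest neighbour is compound 1, and the change from 4-methylphenyl to 2-chlorophenyl gave a 3.0-fold higher number from compound 1 to compound 2 (0.48 log units; beyond the scatter). The next compound, compound 3 with structure `CCCCNC(=S)N1CCC(CC2Cc3cc(OC)c(OC)cc3C2=O)CC1`, has not yet been tested. It differs from compound 2 in one place: butyl in place of 2-chlorophenyl on an amide-type nitrogen. Within the data shown here, no measured step bears directly on this change, since the only step known, a 3.0-fold higher number from compound 1 to compound 2 (0.48 log units; beyond the scatter), exchanges one aromatic group for another and leaves a ring in place, whereas here a ring gives way to a chain. The data give no basis to expect either a lower or a higher number with confidence, so the expectation for compound 3 is a step of about no change at the digits printed from compound 2 to compound 3 (within the scatter), that is, no step beyond the scatter. Compound 3 is therefore estimated at 300 mg/kg in this assay, with a range from 100 mg/kg to 1000 mg/kg.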

Compound 3, minimum effective dose: 100 mg/kg
The estimate for compound 3 lay 3.0-fold (0.48 log units) above the measured number; the measured number falls inside the stated range.
By their numbers in this assay, from the lowest: compounds 1 and 3 (each within the scatter of the next); then compound 2.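

In this assay, the open butyl chain on the amide-type nitrogen serves as well as the 4-methylphenyl ring, with no change at the digits printed from compound 1 to compound 3 (within the scatter), so a ring at this position is not needed to hold that number. Butyl in place of 2-chlorophenyl gives a 3.0-fold lower number from compound 2 to compound 3 (0.48 log units; beyond the scatter), which shows that the aromatic ring does not by itself set the result: among these three groups, 4-methylphenyl and butyl sit together, while 2-chlorophenyl stands apart. Nothing given here explains why 2-chlorophenyl behaves differently from the other two groups.

The compounds shown leave open whether the chlorine or the group's substitution pattern accounts for the higher number of compound 2, a question that a plain phenyl or a 4-chlorophenyl group on the same nitrogen would address. They also leave open how far the chain tolerates change, since only butyl is shown, and a propyl chain, a hexyl chain or a saturated cyclohexyl ring could each give a different answer.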